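The source may hold more compounds than are shown below. What is called first, only, known or untested is meant among the compounds shown, and "the series" means these compounds.

Compound 1 `CCC1C(=O)N(C)c2cnc(Nc3ccc(S(=O)(=O)NC)cc3)nc2N1c1ccn(C)n1`: 12600 nM in a functional assay on A549 cells (Homo sapiens) for antiproliferative activity, read by CCK-8 assay, with a stated time of 72 h; a lower number here means a stronger inhibitor of growth, a higher number a weaker inhibitor of growth.
Compound 2 `CCCNS(=O)(=O)c1ccc(Nc2ncc3c(n2)N(c2ccn(C)n2)C(CC)C(=O)N3C)cc1`: 15000 nM.
Compound 3 `CCCCNC(=O)c1ccc2c(ccn2-c2ncc3c(n2)N(c2ccn(C)n2)C(CC)C(=O)N3C)c1`: 37300 nM.

Compound 4 `CCNC(=O)c1ccc2c(ccn2-c2ncc3c(n2)N(c2ccn(C)n2)C(CC)C(=O)N3C)c1` has not yet been measured. Compound 3 gives the highest number of the three; the difference between its core and that of compound 2 is not broken down here. Between compound 2 and compound 1 the change is hydrogen in place of ethyl on a saturated chain carbon bound to a sulfonamide nitrogen, and it gave a 1.2-fold lower number from compound 2 to compound 1 (0.08 log units; within the scatter). The change from compound 3 to compound 4 is hydrogen in place of ethyl on a saturated chain carbon, two bonds along the chain from an amide-type nitrogen: the same kind of change, though the place differs, being two bonds along the chain from an amide-type nitrogen rather than bound to a sulfonamide nitrogen. Since the earlier step stayed within the scatter, compound 4 is expected to show a 1.1-fold lower number from compound 3 to compound 4 (0.04 log units; within the scatter). Compound 4 is estimated at 34000 nM, between 15000 nM and 80000 nM.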

Compound 4, concentration for 50% growth inhibition: 21700 nM
Compound 4: middle estimate off by 1.6-fold (0.20 log units), on the high side, and the stated range covers the measured number.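

In this assay, going from butyl to ethyl on the amide gave a 1.7-fold lower number from compound 3 to compound 4 (0.24 log units; within the scatter). Going from propyl to methyl on the sulfonamide nitrogen of the other core gave a step that could not be told apart from this one: the same change on two cores in this assay, a 1.2-fold lower number (0.08 log units; within the scatter) from compound 2 to compound 1 and a 1.7-fold lower number (0.24 log units; within the scatter) from compound 3 to compound 4, 1.4-fold (0.16 log units) apart, within the scatter of two such steps. So, in these two pairs, the change carried from one core to the other without a detectable difference, but neither step lies beyond the scatter, so no effect of chain length is shown, and two pairs at different places establish no rule for the series. The compounds shown leave open whether a longer chain, a methyl group on the amide, or an amine at the chain end would shift growth inhibition beyond the scatter. They also leave open how an amide and a sulfonamide compare on a single core.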